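Phenoxy in Place of 2-Methoxyphenyl: Expectation for Compound 4

The compounds below may be only part of what the source reports. "The series", "measured", "known", "first", "only" and "open" are said of these compounds alone.

Of the compounds shown here, three have been measured so far. Compound 1 `O=C(O)CS(=O)(=O)c1ccc(OCc2cccc(-c3ccccc3)c2)cc1` gives 288 nM in a functional assay on CHO cells for agonist activity at Free fatty acid receptor 1 (Homo sapiens), read by FLIPR and calcium flux; on this read-out higher numbers stand for an effect only at larger amounts of compound and lower numbers for an effect already at smaller amounts. Compound 2 `O=C(O)CS(=O)(=O)c1ccc(OCc2cccc(-c3ccccc3C(F)(F)F)c2)cc1` gives 52.5 nM in this assay, and compound 3 `COc1ccccc1-c1cccc(COc2ccc(S(=O)(=O)CC(=O)O)cc2)c1` gives 195 nM in this assay. Among these three numbers compound 3 stands second highest; its nearest neighbour is compound 1, from which it differs only within the scatter, while compound 2 lies furthest from it, beyond the scatter. The steps recorded so far are a 5.5-fold lower number from compound 1 to compound 2 (0.74 log units; beyond the scatter), a 1.5-fold lower number from compound 1 to compound 3 (0.17 log units; within the scatter) and a 3.7-fold higher number from compound 2 to compound 3 (0.57 log units; beyond the scatter).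

Compound 4 `O=C(O)CS(=O)(=O)c1ccc(OCc2cccc(Oc3ccccc3)c2)cc1` has not yet been measured. It differs from compound 3 in one place: phenoxy in place of 2-methoxyphenyl on an aromatic carbon. Going by the values given here, none of the measured steps bears directly on this change; each of them only swaps a small substituent on the outer ring, whereas here the whole outer group is exchanged. The two small swaps around compound 1 and compound 3 stayed within the scatter or moved the number modestly, so no large step is expected.

For compound 4 a step of a 1.5-fold higher number from compound 3 to compound 4 (0.19 log units; within the scatter) in this assay is expected, essentially no change beyond the scatter. Compound 4 is therefore estimated at 300 nM, with a range from 90 nM to 1000 nM.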

Compound 4, half-maximal effective concentration: 97.7 nM
Beside the measured number, compound 4's estimate is 3.1-fold (0.49 log units) above it; the measured number falls inside the stated range.
By their numbers in this assay, from the lowest: compounds 2, 4, 3 and 1 (each within the scatter of the next, the first and the last beyond it).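

At this position, on an aromatic carbon meta to a large group, an outer ring held through an oxygen performs differently from one attached directly: in this assay the exchange of phenyl for phenoxy gives a 2.9-fold lower number from compound 1 to compound 4 (0.47 log units; beyond the scatter), the only one of the three new steps to pass beyond the scatter. Unlike the earlier swaps, which needed a substituent on the outer ring to shift the number, this change does so with an unsubstituted ring, and the result is not separated from either substituted compound: the exchange for 2-methoxyphenyl gives a 2.0-fold lower number from compound 3 to compound 4 (0.30 log units; within the scatter) and the exchange for 2-(trifluoromethyl)phenyl gives a 1.9-fold higher number from compound 2 to compound 4 (0.27 log units; within the scatter). Nothing available explains this behaviour of the phenoxy group.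

The compounds shown leave open whether a trifluoromethyl or methoxy group on the phenoxy ring would act as it did on the phenyl ring, where the trifluoromethyl swap gave a 5.5-fold lower number from compound 1 to compound 2 (0.74 log units; beyond the scatter). They also leave open whether the oxygen link itself is what counts, which a methylene or an amine nitrogen in its place could test.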